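One Ether Chain Exchange in a Flat Series

The compounds below may be only part of what the source reports. "The series", "measured", "known", "first", "only" and "open" are said of these compounds alone.

In a functional assay on RAW264.7 cells (Mus musculus) for inhibition, read by Griess assay, with stated times of 1 h and 24 h (on this read-out lower numbers stand for stronger inhibition and higher numbers for weaker inhibition), compound 3 (`CC(C)=CCOc1ccccc1C1CC(=O)c2ccccc2O1`) reads (32700 nM) and stands within the scatter of compound 1 (`CC(C)CCOc1ccccc1C1CC(=O)c2ccccc2O1`) at (39200 nM) and of compound 2 (`CCCCCOc1ccccc1C1CC(=O)c2ccccc2O1`) at (39200 nM). Compound 4 (`CCCCOc1ccccc1C1CC(=O)c2ccccc2O1`) carries propyl in place of 2-methylprop-1-en-1-yl on a saturated chain carbon bound to an oxygen on an aromatic ring. Three measured exchanges in this chain bear on it: (no change at the digits printed from compound 1 to compound 2 (within the scatter)) and (a 1.2-fold lower number from compound 1 to compound 3 (0.08 log units; within the scatter)) and (a 1.2-fold lower number from compound 2 to compound 3 (0.08 log units; within the scatter)). Going by the values given here, all three stay within the scatter, although no measured compound carries the butoxy chain itself. No step beyond the scatter is therefore expected in this assay. The estimated step is (a 1.1-fold higher number from compound 3 to compound 4 (0.04 log units; within the scatter)). The estimate for compound 4 is (36000 nM), with an expected range from (20000 nM) to (60000 nM).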

Compound 4, half-maximal inhibitory concentration: 48700 nM
Compound 4: middle estimate off by 1.4-fold (0.13 log units), on the low side; measured number inside the range.
By their numbers in this assay, from the lowest: compounds 3, 1, 2 and 4 (each within the scatter of the next).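

In this assay, butoxy takes the place of (3-methylbut-2-en-1-yl)oxy with a 1.5-fold higher number from compound 3 to compound 4 (0.17 log units; within the scatter), so losing the double bond and the branch together does not carry the number beyond the scatter. Shortening the saturated chains to butoxy behaves the same way, with a 1.2-fold higher number from compound 2 to compound 4 (0.09 log units; within the scatter) and a 1.2-fold higher number from compound 1 to compound 4 (0.09 log units; within the scatter). Nothing at hand explains these small differences. As far as these compounds go, whether an amine or a carboxylic acid on this chain, or a much longer chain, would move the number beyond the scatter remains open.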